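A few compounds are considered here, and "the series" means these few. Any claim that something is new, unique, unknown or untested is made for them only; others in the source may bear on it.

Three compounds share one core and differ only in the aromatic groups attached to it. Compound 1 `COc1ccccc1-c1ncnn1-c1cc(OC)c(OC)c(OC)c1` and compound 3 `COc1cc(-n2ncnc2-c2cccc(F)c2)cc(OC)c1OC` reach only the limit of a functional assay on MCF7 cells (Homo sapiens) for antiproliferative activity, read by MTT assay, with a stated time of 72 h; a lower number here means a stronger inhibitor, a higher number a weaker inhibitor. In that assay compound 1 gives > 10000 nM, a limit rather than a number. Compound 3 likewise gives > 10000 nM, also a limit. Going by the values given here, compound 2 `COc1ccc(-n2ncnc2-c2cc(OC)c(OC)c(OC)c2)cc1` is the one compound with a measured number, giving 7400 nM in this assay. The step that the two limits leave unreadable from compound 1 to compound 3 therefore cannot be read, as the limit of > 10000 nM in this assay, at which 2 of the 3 values shown sit, shows. Compound 4 `COc1cc(-c2ncnn2-c2ccc(F)cc2)cc(OC)c1OC` differs from compound 2 by fluoro in place of methoxy on an aromatic carbon. Among the compounds with values here, no measured step reads that change, so the expected shift is a 1.2-fold higher number from compound 2 to compound 4 (0.09 log units; within the scatter), within scatter. Compound 4 is estimated at 9000 nM, between 3000 nM and 30000 nM.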

Compound 4, half-maximal inhibitory concentration: > 10000 nM
Compound 4 ended at the assay's limit (the forecaster's own chance of this, stated with the estimate: 45%); middle value at least 1.1-fold (0.04 log units) from the limit.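

Going by these compounds alone, replacing methoxy with fluoro on this ring gives an at least 1.3-fold higher number from compound 2 to compound 4 (0.13 log units; that floor lies within the scatter) in this assay, the first step in this set that can be read at all, though only as a floor. That floor alone does not establish a real loss, and the true step could be larger. Only a floor can be given because compound 4 reaches a limit rather than a number: the limit of > 10000 nM in this assay, at which 3 of the 4 values shown sit.

As far as these compounds go, it remains open whether an amine or a hydroxyl group at this place, para to a large group, would give a number rather than a limit.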